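Amide aryl variation in the cytotoxicity series

The source may hold more compounds than are shown below. What is called first, only, known or untested is meant among the compounds shown, and "the series" means these compounds.

The series shares one core and varies only the aryl group on the amide-type nitrogen. Compound 1 is `Cc1ccc(NC(=O)c2cccc(/C=C3\CC(=O)N(c4ccccc4)C3=O)c2)cc1C`; in an ADME assay on NCM460 cells (Homo sapiens) for cytotoxicity, read by MTT assay, with a stated time of 72 h (a lower number here means a stronger inhibitor, a higher number a weaker inhibitor), compound 1 gives only a limit of > 100000 nM. Compound 2 is `COc1ccc(OC)c(NC(=O)c2cccc(/C=C3\CC(=O)N(c4ccccc4)C3=O)c2)c1`; in this assay compound 2 gives only a limit of > 100000 nM. Compound 3 is `O=C(Nc1ccc(F)cc1)c1cccc(/C=C2\CC(=O)N(c3ccccc3)C2=O)c1`, and in this assay compound 3 likewise gives only a limit of > 100000 nM. Among the measured compounds shown here, compound 3 thus stands where the other two stand, at the limit of > 100000 nM in this assay, at which 3 of the 3 values shown sit, and none of the measured steps has a readable size: a step that the two limits leave unreadable from compound 1 to compound 2, a step that the two limits leave unreadable from compound 1 to compound 3 and a step that the two limits leave unreadable from compound 2 to compound 3 each run from one limit to another.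

Compound 4 is `CCc1ccc(NC(=O)c2cccc(/C=C3\CC(=O)N(c4ccccc4)C3=O)c2)cc1`. It differs from compound 3 in this way: ethyl in place of fluoro on an aromatic carbon. For the measured compounds named here, the measured steps bear on this change only in that every exchange of the aryl group on the amide-type nitrogen left the read-out at the limit; no step carries a size or a direction to build on. The expectation for compound 4 is therefore that a step that the limit leaves unreadable from compound 3 to compound 4 stays within the scatter and that the assay again reports only a limit. Compound 4 is estimated at 150000 nM, within a range of 60000 nM to 400000 nM.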

Compound 4, half-maximal inhibitory concentration: > 100000 nM
Compound 4: only a limit was reported (the forecaster's own chance of this, stated with the estimate: 85%); the middle value does not contradict the limit.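

Compound 4 gives only a limit in this assay, > 100000 nM, so its steps from compound 1, compound 2 and compound 3 cannot be read, as all four compounds sit at the same limit: the limit of > 100000 nM in this assay, at which 4 of the 4 values shown sit.

The compounds shown leave open whether any exchange of the aryl group on the amide-type nitrogen alters this read-out.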